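The source may hold more compounds than are shown below. What is called first, only, known or untested is meant among the compounds shown, and "the series" means these compounds.

In a functional assay on CCRF-CEM cells (Homo sapiens) for antiproliferative activity, with a stated time of 72 h (on this read-out lower numbers stand for stronger inhibition and higher numbers for weaker inhibition), compound 1 `OC[C@H]1O[C@@H](n2cnc3c(NCc4cccc(Br)c4)ncnc32)[C@H](O)[C@@H]1O` gives 5000 nM and compound 2 `OC[C@H]1O[C@@H](n2cnc3c(NCc4ccc(Cl)c(Cl)c4)ncnc32)[C@H](O)[C@@H]1O` gives 3800 nM; between them lies a 1.3-fold lower number from compound 1 to compound 2 (0.12 log units; within the scatter). Compound 3 `COc1cccc(CNc2ncnc3c2ncn3[C@@H]2O[C@H](CO)[C@@H](O)[C@H]2O)c1OC` reaches only a limit of this assay, > 166000 nM, so it stands at the weak end of the three. Both an at least 33-fold higher number from compound 1 to compound 3 (1.52 log units; beyond the scatter) and an at least 43-fold higher number from compound 2 to compound 3 (1.64 log units; beyond the scatter) were large losses. Compound 4 `Cc1cccc(CNc2ncnc3c2ncn3[C@@H]2O[C@H](CO)[C@@H](O)[C@H]2O)c1O` differs from compound 3 by 2-hydroxy-3-methylphenyl in place of 2,3-dimethoxyphenyl on a saturated chain carbon bound to a nitrogen on an aromatic ring. Going by the values given here, no measured step carries a 2-hydroxy-3-methylphenyl group, so the two large steps ending at compound 3 show only that the 2,3-dimethoxyphenyl was poorly tolerated. Compound 4 is therefore expected near 50000 nM, within 8000 nM to 166000 nM. That estimate means an at least 3.3-fold lower number from compound 3 to compound 4 (0.52 log units; beyond the scatter), a guess drawn from a limit and so uncertain.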

Compound 4, half-maximal inhibitory concentration: 900 nM
Compound 4: middle estimate off by 56-fold (1.74 log units), on the high side; measured number below the stated range.
By their numbers in this assay, from the lowest: compound 4; then compounds 2 and 1 (each within the scatter of the next). At a limit, above all of these: compound 3.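

Replacing the 2,3-dimethoxyphenyl with 2-hydroxy-3-methylphenyl in this assay gives an at least 180-fold lower number from compound 3 to compound 4 (2.26 log units; beyond the scatter), so the earlier loss belongs to that particular ring and not to this position as a whole. The size of that step is only a bound, as compound 3 stands at a limit: the limit of > 166000 nM in this assay, at which 1 of the 4 values shown sits. The new group also outdoes both halogen-bearing rings, with a 4.2-fold lower number from compound 2 to compound 4 (0.63 log units; beyond the scatter) and a 5.6-fold lower number from compound 1 to compound 4 (0.74 log units; beyond the scatter), so no halogen is needed here for activity. The compounds shown do not separate the share of the hydroxy group from that of the methyl group. As far as these compounds go, what an amine or a carboxylic acid on that phenyl ring, or a longer chain, would do also stays open.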